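The source may report more compounds than this note shows. Statements on the series, on what has been measured and on what is new or still open speak of the compounds shown alone.

Measured in an assay for inhibition of Polyunsaturated fatty acid 5-lipoxygenase (Homo sapiens), read by HPLC, with a stated time of 15 min; a lower number here means a stronger inhibitor, a higher number a weaker inhibitor:
compound 1 `COc1cc(-c2nc3ccc(C)cn3c2NC2CCCCC2)ccc1OCCCNC(=O)Nc1ccc(C(F)(F)F)cc1` gives 439 nM
compound 2 `COc1cc(-c2nc3ccc(C)cn3c2NC2CCCC2)ccc1OCCCNC(=O)Nc1ccc(C(F)(F)F)cc1` gives 614 nM
compound 3 `COc1cc(-c2nc3ccc(C)cn3c2NC(C)C)ccc1OCCCNC(=O)Nc1ccc(C(F)(F)F)cc1` gives 620 nM

Compound 1 carries the lowest number of the three, but a 1.4-fold higher number from compound 1 to compound 2 (0.15 log units; within the scatter) and a 1.4-fold higher number from compound 1 to compound 3 (0.15 log units; within the scatter) both lie within the scatter, as does a 1.0-fold higher number from compound 2 to compound 3 (0.00 log units; within the scatter); the three amine variants on the aromatic ring nitrogen cannot be told apart on these numbers. Compound 4 `COc1cc(-c2nc3ccc(C)cn3c2NC2CCCCC2)ccc1OCCCNC(=O)NC1CCCCC1` alters a different part of the molecule: cyclohexyl in place of 4-(trifluoromethyl)phenyl on an amide-type nitrogen. Within the data shown here, none of the measured steps touches the urea end, so the expectation for compound 4 in this assay rests on no direct precedent; the step of a 2.1-fold higher number from compound 1 to compound 4 (0.31 log units; beyond the scatter) is expected to be modest at its centre, with a wide band in both directions. Compound 4 is estimated at 900 nM, range 250 nM to 4000 nM.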

Compound 4, half-maximal inhibitory concentration: 190 nM
For compound 4 the middle estimate is 4.7-fold (0.68 log units) above the measured one, outside the stated range (below it).
By their numbers in this assay, from the lowest: compound 4; then compounds 1, 2 and 3 (each within the scatter of the next).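

In this assay, the urea end responds where the amine variants did not: cyclohexyl in place of 4-(trifluoromethyl)phenyl on an amide-type nitrogen gives a 2.3-fold lower number from compound 1 to compound 4 (0.36 log units; beyond the scatter), a step beyond the scatter. An aromatic ring at this position is therefore not required for inhibition in this pair, and a non-aromatic carbon ring with fewer heavy atoms is accepted. No available measurement bears on the reason for this step.

From the compounds shown here alone, whether the lower number tracks ring size or loss of aromaticity remains open, and cyclopentyl, isopropyl or unsubstituted phenyl on this nitrogen would help separate the two. Also open, going by these compounds, is whether the amine variants stay indistinguishable when the urea end carries cyclohexyl.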